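This account rests on a few compounds, and the source may have more. Where it says the series, first, only, none or still open, it means among the compounds named here.

Measured in a functional assay on HeLa cells (Homo sapiens) for inhibition; a higher number here means a weaker inhibitor of growth, a lower number a stronger inhibitor of growth:
- compound 1 `COC(=O)c1ccsc1NC(=O)[C@@H]1CCCN1`: > 250 ug/mL
- compound 2 `O=C1CC[C@@H](COC(=O)c2ccsc2NC(=O)[C@@H]2CCCN2)N1`: 191 ug/mL
- compound 3 `O=C(OCC(F)(F)F)c1ccsc1NC(=O)[C@@H]1CCCN1`: 109 ug/mL

Compound 1 stands at the limit of > 250 ug/mL in this assay, at which 1 of the 3 values shown sits, which is a limit and not a number. Compound 4 `COC(=O)c1ccsc1NC(=O)[C@H]1CCCN1` is related to it as follows: the two compounds have the same atoms and bonds and differ only in configuration as drawn: 1 of 1 stereo elements differ; a stereocentre at a saturated ring carbon is drawn S in compound 1 and R in compound 4. Among the measured compounds shown here, no measured step changes that configuration. The nearest are an at least 1.3-fold lower number from compound 1 to compound 2 (0.11 log units; that floor lies within the scatter) and an at least 2.2-fold lower number from compound 1 to compound 3 (0.36 log units; beyond the scatter), and both are made on a saturated chain carbon bound to an oxygen next to a carbonyl group. They therefore give neither a size nor a direction for this change in this assay, and no step beyond the scatter is expected. The expected step is a number no higher from compound 1 to compound 4 (the limit leaves the size open). For compound 4 the estimate is 250 ug/mL, with an expected range from 130 ug/mL to 450 ug/mL.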

Compound 4, concentration for 50% growth inhibition: 91.4 ug/mL
The estimate for compound 4 lay 2.7-fold (0.44 log units) above the measured number; the whole stated range lies above it.
By their numbers in this assay, from the lowest: compounds 4, 3 and 2 (each within the scatter of the next, the first and the last beyond it). At a limit, above all of these: compound 1.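

In this assay, the stereocentre at the saturated ring carbon matters on its own, with an at least 2.7-fold lower number from compound 1 to compound 4 (0.43 log units; beyond the scatter). The earlier steps shown here all lay on the saturated chain carbon bound to an oxygen next to a carbonyl group, whereas here nothing enters or leaves, so the step can be assigned to configuration alone: the fact that compounds 1 and 4 differ only in the configuration as drawn. Compound 1 stands at a limit, so this step gives only a floor for the size: the limit of > 250 ug/mL in this assay, at which 1 of the 4 values shown sits.

On these data alone, it remains open whether the R configuration gives a similar step alongside the trifluoromethyl group of compound 3. As far as these compounds go, what a longer chain or a carboxylic acid would do in that place is also open.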